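The source may hold more compounds than are shown below. What is called first, only, known or untested is meant among the compounds shown, and "the series" means these compounds.

Measured compounds in a toxicity assay on THP-1 cells (Homo sapiens) for inhibition; a lower number here means that less compound is tolerated, a higher number that more compound is tolerated:
- Compound 1, `COc1ccc(-c2cnc(NC(=O)c3cccnc3)n2C)cc1`: compound 1 gives > 100000 nM, a limit of the assay.
- Compound 2, `COc1ccc(-c2cnc(NC(=O)c3ccco3)n2C)cc1`: compound 2 gives > 100000 nM, a limit of the assay.
- Compound 3, `COc1ccc(-c2cnc(NC(=O)c3cccc(C#N)c3)n2C)cc1`: compound 3 gives > 100000 nM, a limit of the assay.

Compound 3 stands at the same limit as the other two; all three sit at the limit of > 100000 nM in this assay, at which 3 of the 3 values shown sit, so none is distinguished from another. The steps a step that the two limits leave unreadable from compound 1 to compound 2, a step that the two limits leave unreadable from compound 1 to compound 3 and a step that the two limits leave unreadable from compound 2 to compound 3 are therefore unreadable in size.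

The next compound, compound 4, is `COc1ccc(-c2cnc(NC(=O)c3ccccc3Br)n2C)cc1`. The change from compound 3 is 2-bromophenyl in place of 3-cyanophenyl on a carbonyl carbon. The three measured steps all concern the same carbonyl carbon, and each left the value at the limit. Within the data shown here, no step therefore gives a size for this new exchange in this assay; the expectation is none beyond the scatter, with compound 4 again at the limit. The estimated step that the limit leaves unreadable from compound 3 to compound 4 is expected to be flat. Compound 4 is expected to give 150000 nM, within 50000 nM to 400000 nM.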

Compound 4, half-maximal cytotoxic concentration: > 100000 nM
Compound 4 gave a limit, no number; the forecaster's own chance of this, stated with the estimate: 85%; the middle value is on the limit's open side.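

The steps from compounds 1, 2 and 3 to compound 4 cannot be read in this assay, since all four compounds stand at one limit: the limit of > 100000 nM in this assay, at which 4 of the 4 values shown sit.

The compounds shown leave open at what concentration any of them becomes toxic, and whether the groups on the carbonyl carbon differ at all.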